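A few compounds are considered here, and "the series" means these few. Any claim that something is new, unique, unknown or untested is made for them only; others in the source may bear on it.

Measured in a functional assay on CCRF-CEM cells (Homo sapiens) for antiproliferative activity, read by MTT assay; on this read-out higher numbers stand for weaker inhibition and lower numbers for stronger inhibition:
- compound 1 `C/C(=N\Nc1nc2ccccc2o1)c1cnc(C)cn1`: 620 nM
- compound 2 `C/C(=N\Nc1nc2ccccc2o1)c1ncccn1`: 130 nM
- compound 3 `C/C(=N\Nc1nc2ccccc2o1)c1nccnc1C`: 1300 nM

Compound 3 has the highest number of the three, and so the weakest inhibition. Compound 1 lies nearest to it and compound 2 furthest, both at lower numbers and both beyond the scatter.

The next compound is compound 4 `C/C(=N\Nc1nc2ccccc2o1)c1cnccn1`, which differs from compound 3 as follows: hydrogen in place of methyl on an aromatic carbon. In words, this is hydrogen in place of methyl on an aromatic carbon.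

For the measured compounds named here, no measured pair isolates this change, so the expectation rests on indirect evidence. Compound 2, which carries no methyl on its ring, gives 130 nM, while compound 1, which does carry one, gives 620 nM. A step to a lower number in this assay, beyond the scatter, is therefore expected, and its estimated size is a 4.6-fold lower number from compound 3 to compound 4 (0.67 log units; beyond the scatter). For compound 4 the estimated value is 280 nM, with an expected range of 90 nM to 850 nM.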

Compound 4, half-maximal inhibitory concentration: 430 nM
Beside the measured number, compound 4's estimate is 1.5-fold (0.19 log units) below it; the measured number falls inside the stated range.
By their numbers in this assay, from the lowest: compound 2; then compounds 4 and 1 (each within the scatter of the next); then compound 3.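

In this assay, hydrogen in place of methyl on the aromatic carbon ortho to a large group gives a 3.0-fold lower number from compound 3 to compound 4 (0.48 log units; beyond the scatter), so a methyl at this place goes with weaker inhibition than hydrogen. The same exchange at the methyl of compound 1 gives a 1.4-fold lower number from compound 1 to compound 4 (0.16 log units; within the scatter), so the two compounds cannot be told apart, and the effect of a methyl on this ring depends on which carbon carries it. Pyrazin-2-yl in place of pyrimidin-2-yl gives a 3.3-fold higher number from compound 2 to compound 4 (0.52 log units; beyond the scatter), so the choice of ring also shifts the number when neither ring carries a methyl.

As far as these compounds go, it remains open whether the step at this place follows the size of the group, as an ethyl or a methoxy would show. From the compounds shown here alone, an amine or a chlorine at this place is equally open. Nothing here gives a measured reason for any of these steps.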